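The source may hold more compounds than are shown below. What is called first, only, known or untested is meant among the compounds shown, and "the series" means these compounds.

Compound 1 is `CCCCCCCCCCCCCCNC(=O)[C@H](CO)/N=C/c1ccccc1`; in a functional assay on cells (Homo sapiens) for cytotoxicity, read by MTT assay, with a stated time of 24 h (a lower number here means a stronger inhibitor, a higher number a weaker inhibitor), compound 1 gives 7670 nM.
Compound 2 is `CCCCCCCCCCCCCCNC(=O)[C@H](CO)/N=C/c1ccccc1O`; in this assay compound 2 gives 19000 nM.
Compound 3 is `CCCCCCCCCCCCCCNC(=O)[C@H](CO)/N=C/c1cccc(O)c1`; in this assay compound 3 gives 32600 nM.

Among these three, compound 3 has the highest number, and therefore the weakest effect, in this assay. Its nearest neighbour is compound 2, and the step of a 1.7-fold higher number from compound 2 to compound 3 (0.23 log units; within the scatter), so those two cannot be told apart. The clearer difference is to compound 1, with a 4.3-fold higher number from compound 1 to compound 3 (0.63 log units; beyond the scatter).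

Compound 4 is `CCCCCCCCCCCCCCNC(=O)[C@H](CO)/N=C/c1ccccc1Cl`. The change from compound 3 is 2-chlorophenyl in place of 3-hydroxyphenyl on a carbon with a double bond to nitrogen. Two earlier steps bear on it. Adding a hydroxy group to the ring of compound 1 raised the number both times: a 2.5-fold higher number from compound 1 to compound 2 (0.39 log units; beyond the scatter) and a 4.3-fold higher number from compound 1 to compound 3 (0.63 log units; beyond the scatter). Taking the hydroxy group away again should, on that evidence, bring the number back down toward that of compound 1. Among the measured compounds shown here, the chlorine that enters has no precedent in this set, so its own contribution is unknown and widens the range. Compound 4 is therefore expected to give about 9000 nM in this assay, somewhere between 3500 nM and 25000 nM. That estimate corresponds to an expected step of a 3.6-fold lower number from compound 3 to compound 4 (0.56 log units; beyond the scatter).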

Compound 4, half-maximal inhibitory concentration: 10300 nM
Beside the measured number, compound 4's estimate is 1.1-fold (0.06 log units) below it; the range from low to high includes it.
By their numbers in this assay, from the lowest: compounds 1, 4, 2 and 3 (each within the scatter of the next, the first and the last beyond it).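

With the 2-chlorophenyl group, the result cannot be separated from that of the plain phenyl group, a 1.3-fold higher number from compound 1 to compound 4 (0.13 log units; within the scatter), or from that of the 2-hydroxyphenyl group, a 1.8-fold lower number from compound 2 to compound 4 (0.27 log units; within the scatter), so in this assay a chloro group at this place on the ring has no readable effect on the number. Among the compounds shown here, the one step beyond the scatter, a 3.2-fold lower number from compound 3 to compound 4 (0.50 log units; beyond the scatter), changes both the group and its place on the ring, so it cannot be assigned to either change alone. Nothing measured on these compounds accounts for these steps.

As far as these compounds go, it remains open whether a chloro group elsewhere on the ring would give a similar number. From the compounds shown here alone, the effect of a methoxy group or an amine in place of the chloro group also remains unknown.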